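Replacing the nitro group on the amide benzene ring

The source may report more compounds than this note shows. Statements on the series, on what has been measured and on what is new or still open speak of the compounds shown alone.

Of the compounds shown here, three sharing one core have been measured in an assay on HEK293 cells for antagonist activity at P2X purinoceptor 7 (Homo sapiens), read by fluorescence, with a stated time of 2 h; a higher number here means a weaker inhibitor, a lower number a stronger inhibitor. Compound 1 `COc1ccc(C(=O)N2CCC(n3cncc3-c3ccc(OS(=O)(=O)c4cccc5cnccc45)cc3)CC2)cc1` gives 77 nM. Compound 2 `COc1ccc(C(=O)N2CCC(n3cncc3-c3ccc(OS(=O)(=O)c4cccc5cnccc45)cc3)CC2)cc1OC`, which carries one more methoxy group, gives 259 nM; the step of a 3.4-fold higher number from compound 1 to compound 2 (0.53 log units; beyond the scatter) shows that this addition weakened inhibition. Compound 3 `O=C(c1ccc([N+](=O)[O-])cc1)N1CCC(n2cncc2-c2ccc(OS(=O)(=O)c3cccc4cnccc34)cc2)CC1` gives 1.49 nM, the lowest of the three numbers, and it stands well apart from both of the others: the steps of a 52-fold lower number from compound 1 to compound 3 (1.71 log units; beyond the scatter) and a 170-fold lower number from compound 2 to compound 3 (2.24 log units; beyond the scatter) are both large and far beyond the scatter.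

Compound 4 `CN(C)c1cccc(C(=O)N2CCC(n3cncc3-c3ccc(OS(=O)(=O)c4cccc5cnccc45)cc3)CC2)c1` has not yet been measured. It differs from compound 3 in one place: 3-(dimethylamino)phenyl in place of 4-nitrophenyl on a carbonyl carbon. The nitro group that set compound 3 apart is therefore gone. The two steps that bear on this are those leading into compound 3, a 52-fold lower number from compound 1 to compound 3 (1.71 log units; beyond the scatter) and a 170-fold lower number from compound 2 to compound 3 (2.24 log units; beyond the scatter), both of which were large gains tied to the nitro group. Removing it is expected to reverse much of that gain, so a large rise in this assay is expected, roughly back to the level of compound 1 or somewhat above it; the estimated step is a 100-fold higher number from compound 3 to compound 4 (2.00 log units; beyond the scatter). For compound 4 the estimate is 150 nM, with a range from 30 nM to 700 nM.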

Compound 4, half-maximal inhibitory concentration: 155 nM
The estimate for compound 4 lay 1.0-fold (0.01 log units) below the measured number; measured number inside the range.
By their numbers in this assay, from the lowest: compound 3; then compounds 1, 4 and 2 (each within the scatter of the next, the first and the last beyond it).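

Going by these compounds alone, the low number of compound 3 did not survive this swap in this assay: with 3-(dimethylamino)phenyl on the carbonyl carbon, the step is a 100-fold higher number from compound 3 to compound 4 (2.02 log units; beyond the scatter), a large loss that the earlier compounds could only hint at, since none of them tested a nitrogen-bearing replacement for the nitro group. Compound 4 also falls in with the two methoxy-bearing compounds, with steps of a 1.7-fold lower number from compound 2 to compound 4 (0.22 log units; within the scatter) and a 2.0-fold higher number from compound 1 to compound 4 (0.30 log units; within the scatter), so among these four compounds only the 4-nitrophenyl amide stands clearly apart, even though compounds 1 and 2 remain separated from each other beyond the scatter. Nothing measured here explains the size of this step.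

This swap changes both the group and its numbered place on the benzene ring, so the loss cannot be assigned to either one alone. A 3-nitrophenyl or a 4-(dimethylamino)phenyl on the same carbonyl carbon would separate the two, and a 4-cyanophenyl, with a nitrile in place of the nitro group, would ask whether anything other than nitro can reach the level of compound 3.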